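The source may report more compounds than this note shows. Statements on the series, on what has been measured and on what is new or still open speak of the compounds shown alone.

Compound 1 `CCOC(=O)N1CCC(Oc2ncnc3c2CCN3c2ccc(S(C)(=O)=O)cc2F)CC1` gives 251 nM in a functional assay on CHO-K1 cells for agonist activity at Glucose-dependent insulinotropic receptor (Homo sapiens), read by a luciferase reporter, with a stated time of 5 h; a higher number here means that more compound is needed for the effect, a lower number that less compound is needed. Compound 2 `CS(=O)(=O)c1ccc(N2CCc3c(OC4CCN(C(=S)Sc5ccccc5)CC4)ncnc32)c(F)c1` gives 12.6 nM, and the change of the substituent on the amine nitrogen in the ring produces a 20-fold lower number from compound 1 to compound 2 (1.30 log units; beyond the scatter). Compound 3 `CC(C)OC(=O)N1CCC(Oc2ncnc3c2CCN3c2ccc(S(C)(=O)=O)cn2)CC1` gives 126 nM; this number and that of compound 1 lie within the scatter of each other, while the number of compound 2 lies clearly lower, beyond the scatter. Compound 4 `CSc1ccc(N2CCc3c(OC4CCN(C(=O)OC(C)C)CC4)ncnc32)cc1F` differs from compound 3 only at the nitrogen on the aromatic ring in the five-membered ring: a group of 9 heavy atoms (7 carbon, 1 fluorine, 1 sulfur; one six-membered aromatic ring of carbon only) in place of a group of 10 heavy atoms (6 carbon, 1 nitrogen, 2 oxygen, 1 sulfur; one six-membered aromatic ring with 1 hetero atom), on a nitrogen on an aromatic ring in a ring. For the measured compounds named here, the one measured step, from compound 1 to compound 2, concerns the group on the amine nitrogen in the piperidine-like ring, not this position, so no measured step bears directly on the change; compounds 1 and 3 differ at this position and elsewhere at once, and their values show no difference beyond the scatter. Compound 4 is therefore expected to show a 1.6-fold higher number from compound 3 to compound 4 (0.20 log units; within the scatter), a step no larger than the scatter. Compound 4 is estimated at 200 nM, in the range 60 nM to 700 nM.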

Compound 4, half-maximal effective concentration: 398 nM
For compound 4 the middle estimate is 2.0-fold (0.30 log units) below the measured one; measured number inside the range.
By their numbers in this assay, from the lowest: compound 2; then compounds 3, 1 and 4 (each within the scatter of the next, the first and the last beyond it).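

In this assay the position on the nitrogen on an aromatic ring now has a step of its own, a 3.2-fold higher number from compound 3 to compound 4 (0.50 log units; beyond the scatter), whereas compounds 1 and 3 differ there and elsewhere at once and so gave no reading of this position alone. The position is therefore not indifferent to its group: of this pair, the 5-(methylsulfonyl)pyridin-2-yl group goes with the lower number, though the step is only modest. Nothing given here accounts for this step.

The change replaces the ring, its hetero atom and its substituents together, so the compounds shown do not tell which part of it carries the step. Also open, as far as these compounds go, is how a nitrile or a carboxylic acid on this aromatic ring would read, and whether the group on the amine nitrogen of compound 2 would keep its lower number alongside a different group here.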